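Trading a pyrrolidine amine for a bromine atom

The compounds below may be only part of what the source reports. "The series", "measured", "known", "first", "only" and "open" are said of these compounds alone.

Of the compounds shown here, two have been measured in an assay on isolated protein for inhibition of tyrosine-protein kinase receptor UFO (Homo sapiens), with a stated time of 1.5 h; a higher number here means a weaker inhibitor, a lower number a stronger inhibitor. Compound 1, with structure `Clc1cc2[nH]nc(-c3cnn(-c4ccccc4)c3)c2cc1N[C@@H]1CCNC1`, gives 1700 nM in this assay. Compound 2, with structure `CNC1CCN(c2ccc3[nH]nc(-c4cnn(C)c4)c3c2)C1`, gives 432000 nM in this assay. Compound 2 therefore stands at the highest number of the two, and compound 1 sits a long way beneath it, a gap that lies well beyond the usual scatter. Compounds 1 and 2 differ in several places at once, so no single change can be read from them.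

Compound 3, with structure `Cn1cc(-c2n[nH]c3ccc(Br)cc23)cn1`, has not yet been measured. It arises from compound 2 by the change (bromo in place of 3-(methylamino)pyrrolidin-1-yl on an aromatic carbon). The 3-(methylamino)pyrrolidin-1-yl group that leaves is the only hydrogen-bond donor and the only acceptors in that part of the molecule, while the bromo that enters is a single atom with neither.

Since compound 2 already sits at a very high number, the step to compound 3 is expected to be modest in either direction, most likely a small move toward a lower number, as given by a 2.9-fold lower number from compound 2 to compound 3 (0.46 log units; beyond the scatter). Compound 3 is estimated to give 150000 nM in this assay, within a range from 15000 nM to 1500000 nM.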

Compound 3, half-maximal inhibitory concentration: 1540 nM
Compound 3: the middle estimate sits 97-fold (1.99 log units) above what was measured; measured number outside the range, below it.
By their numbers in this assay, from the lowest: compounds 3 and 1 (each within the scatter of the next); then compound 2.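

In this assay, among these compounds, putting bromo in place of 3-(methylamino)pyrrolidin-1-yl on this aromatic carbon gives a 280-fold lower number from compound 2 to compound 3 (2.45 log units; beyond the scatter), a large step and the first change in this set that can be read at a single place. It shows that what sits at this position has a strong bearing on the result, and that the pyrrolidine group, with its ring, its hydrogen-bond donor and its hydrogen-bond acceptors, is not required for inhibition in this assay, since a single bromine atom in its place gives the much lower number. Nothing measured here accounts for the size of this step, so it records an outcome and not an explanation.

Still open, going by these compounds, is which part of the change matters, as the ring, the amine and the number of heavy atoms all change together in this one step. A fluorine atom, a methoxy group or an open-chain amine on this same carbon would be needed to tell whether the bromine itself matters or whether the removal of the pyrrolidine group alone accounts for the step.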